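Swapping the aryl arm for a methyl on the shared core

This account rests on a few compounds, and the source may have more. Where it says the series, first, only, none or still open, it means among the compounds named here.

Measured so far in a functional assay on AGS cells (Homo sapiens) for cytotoxicity, read by MTT assay, with a stated time of 48 h; on this read-out lower numbers stand for stronger inhibition and higher numbers for weaker inhibition:
Compound 1 `Cc1nc2c3ccccc3ccc2c2nc3c(ccc4ccccc43)c(-c3cccc([N+](=O)[O-])c3)c12` gives 25500 nM.
Compound 2 `Cc1nc2c3ccccc3ccc2c2nc3c(ccc4ccccc43)c(-c3ccccc3N)c12` gives 12100 nM.
Compound 3 `Cc1nc2c3ccccc3ccc2c2nc3c(ccc4ccccc43)c(-c3cc(O)nc4ccccc34)c12` gives 15800 nM.

Compound 2 has the lowest number of the three, yet only its gap to compound 1 stands beyond the scatter; its gap to compound 3 does not, so compound 2 and compound 3 cannot be ranked against each other. For the measured compounds named here, the step of a 2.1-fold lower number from compound 1 to compound 2 (0.32 log units; beyond the scatter) is the single clear change seen; a 1.6-fold lower number from compound 1 to compound 3 (0.21 log units; within the scatter) and a 1.3-fold higher number from compound 2 to compound 3 (0.12 log units; within the scatter) stay within the scatter.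

Compound 4 `Cc1nc2c3ccccc3ccc2c2nc3c(ccc4ccccc43)c(C)c12` is not yet measured. It differs from compound 2 by methyl in place of 2-aminophenyl on an aromatic carbon. Here the whole aromatic arm is removed rather than exchanged, and no measured pair covers that. The three steps above show that swapping one aryl group for another moves the number at most modestly, which hints that this position tolerates variation, but compound 4 goes further than any of them. The step of a 1.8-fold higher number from compound 2 to compound 4 (0.26 log units; within the scatter) is therefore expected to be small and uncertain in direction. Compound 4 is estimated at 22000 nM, within 8000 nM to 60000 nM.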

Compound 4, half-maximal inhibitory concentration: > 80000 nM
Compound 4 was reported as a limit; the forecaster's own chance of this, stated with the estimate: 20%; middle value at least 3.6-fold (0.56 log units) away from the limit.
By their numbers in this assay, from the lowest: compounds 2, 3 and 1 (each within the scatter of the next, the first and the last beyond it). At a limit, above all of these: compound 4.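

In this assay compound 4 is reported as a limit, not as a number: the limit of > 80000 nM in this assay, at which 1 of the 4 values shown sits.

Replacing the arm with methyl raises the number whichever aromatic arm it replaces, giving an at least 6.6-fold higher number from compound 2 to compound 4 (0.82 log units; beyond the scatter), an at least 5.0-fold higher number from compound 3 to compound 4 (0.70 log units; beyond the scatter) and an at least 3.1-fold higher number from compound 1 to compound 4 (0.49 log units; beyond the scatter). The earlier swaps of one aromatic arm for another moved the number modestly at most, so they could not show what this change shows: among these four compounds, a measurable number appears only with an aromatic arm on this carbon, and no compound goes against that.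

As far as these compounds go, it remains open whether the aromatic ring itself matters or whether any larger group would serve, and a cyclohexyl ring or a longer alkyl chain on this carbon would help separate those two possibilities. Plain phenyl would likewise help show whether the amine of the 2-aminophenyl group, the nitro group of compound 1 or the hydroxyl group of compound 3 contributes anything beyond the ring that carries it.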